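The source may hold more compounds than are shown below. What is called first, only, known or untested is meant among the compounds shown, and "the series" means these compounds.

Compound 1 `O=C(Nc1cccc(-c2oc3cc(-c4ccc(F)cc4)ccc3c(=O)c2O)c1)c1ccccc1F` and compound 2 `COc1ccc(C(=O)Nc2cccc(-c3oc4cc(-c5ccc(F)cc5)ccc4c(=O)c3O)c2)cc1` share one core; they differ only in the aryl group on the amide carbonyl. In a functional assay on HepG2 cells (Homo sapiens) for antiproliferative activity, read by CCK-8 assay, with a stated time of 72 h (a higher number here means a weaker inhibitor, a lower number a stronger inhibitor), compound 1 gives 10100 nM, and compound 2 gives 8420 nM. The step of a 1.2-fold lower number from compound 1 to compound 2 (0.08 log units; within the scatter) is the only measured one in the set. Compound 2 holds the lowest of the two numbers in this assay, but its distance to compound 1 sits inside the scatter, so no order between the two can be claimed.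

Compound 3 `Cc1ccc(C(=O)Nc2cccc(-c3oc4cc(-c5ccc(F)cc5)ccc4c(=O)c3O)c2)cc1` is the next member. The change from compound 2 is methyl in place of methoxy on an aromatic carbon. Going by the values given here, only the step of a 1.2-fold lower number from compound 1 to compound 2 (0.08 log units; within the scatter) bears on it, as a change within the same aryl group on the carbonyl, and that step stayed inside the scatter. A small group swap at the same place is therefore expected to give no step beyond the scatter in this assay, in either direction. For compound 3 the expected value is 8500 nM, with a range from 4000 nM to 18000 nM, which means an expected step of a 1.0-fold higher number from compound 2 to compound 3 (0.00 log units; within the scatter).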

Compound 3, half-maximal inhibitory concentration: 2320 nM
For compound 3 the middle estimate is 3.7-fold (0.56 log units) above the measured one; the measured number lies below the stated range.
By their numbers in this assay, from the lowest: compound 3; then compounds 2 and 1 (each within the scatter of the next).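

The aryl group on the amide carbonyl is not a flat position, as the pair of compound 1 and compound 2 alone seemed to suggest: in this assay, methyl in place of methoxy, para to a large group, gives a 3.6-fold lower number from compound 2 to compound 3 (0.56 log units; beyond the scatter). The 4-methylphenyl group also separates from the 2-fluorophenyl group, with a 4.4-fold lower number from compound 1 to compound 3 (0.64 log units; beyond the scatter), so the aryl group at this place can shift the read-out beyond the scatter, and a swap as small as methoxy to methyl is enough to do so. Nothing available explains why methyl and methoxy differ at this position.

Still open, going by these compounds, is whether the shift belongs to methyl itself or would appear with other groups at the same place, such as an ethyl group, a chlorine, an amine or a carboxylic acid. Also open, on these data alone, is whether the 4-methylphenyl group keeps this effect with a different group in place of the 4-fluorophenyl on the shared core, and whether a methyl elsewhere on the same aryl ring behaves alike.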